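Amine-substituted quinone core: arylamino to cyclopentylamino

The source may report more compounds than this note shows. Statements on the series, on what has been measured and on what is new or still open speak of the compounds shown alone.

Measured compounds:
compound 1 `Cc1ccc(NC2=CC(=O)c3nc4n(c3C2=O)[C@H]2OC[C@@H](O)[C@H]2OC4)cc1` gives 1420 nM
compound 2 `Cc1ccc(NC2=CC(=O)c3c(nc4n3[C@H]3OC[C@@H](O)[C@H]3OC4)C2=O)cc1C` gives 1050 nM
compound 3 `Cc1ccc(NC2=CC(=O)c3c(nc4n3[C@H]3OC[C@@H](O)[C@H]3OC4)C2=O)cc1` gives 1550 nM

All three numbers come from a functional assay on MGC-803 cells (Homo sapiens) for inhibition, read by sulforhodamine B assay; on this read-out higher numbers stand for weaker inhibition and lower numbers for stronger inhibition. Compound 1 sits in the middle of the three: its nearest neighbour is compound 3, its furthest is compound 2, and both gaps lie within the scatter, so the three compounds cannot be told apart on these numbers. Within the data shown here, the one step between measured compounds that differ in a single place is a 1.5-fold higher number from compound 2 to compound 3 (0.17 log units; within the scatter), and it too stays within the scatter.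

Compound 4 `O=C1C=C(NC2CCCC2)C(=O)c2c1nc1n2[C@H]2OC[C@@H](O)[C@H]2OC1` differs from compound 1 as follows: cyclopentyl in place of 4-methylphenyl on an amine nitrogen. Every measured compound keeps an arylamino group on the same nitrogen, and the only variation seen so far is on the aryl ring itself. Among the measured compounds shown here, no measured step therefore bears on exchanging the whole aryl group for a saturated ring; the data give no basis to expect a step in either direction beyond the scatter, only a wide uncertainty.

For compound 4 the step of a 1.5-fold higher number from compound 1 to compound 4 (0.19 log units; within the scatter) is expected to be small, with the number estimated at 2200 nM and a range from 700 nM to 7000 nM.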

Compound 4, half-maximal inhibitory concentration: > 8000 nM
Compound 4: a limit, no number (the forecaster's own chance of this, stated with the estimate: 5%); middle value at least 3.6-fold (0.56 log units) away from the limit.
By their numbers in this assay, from the lowest: compounds 2, 1 and 3 (each within the scatter of the next). At a limit, above all of these: compound 4.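

In this assay, compound 4 stands at a limit of the assay rather than at a number: the limit of > 8000 nM in this assay, at which 1 of the 4 values shown sits. On the amine nitrogen, cyclopentyl in place of 4-methylphenyl gives an at least 5.6-fold higher number from compound 1 to compound 4 (0.75 log units; beyond the scatter), so inhibition in this assay weakens with this exchange, and the true size of the step may be larger than the limit allows it to show. The only earlier single-place change, hydrogen in place of methyl on the aryl ring, gave a 1.5-fold higher number from compound 2 to compound 3 (0.17 log units; within the scatter), so among the compounds shown this position tolerates that small edit on the aryl ring, while exchanging the whole aryl group for a saturated ring is the first change here to reach beyond the scatter.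

The compounds shown do not separate the aromatic ring from ring size or from the methyl group, and cyclohexyl, benzyl or unsubstituted phenyl on the same nitrogen would bear on that question. As far as these compounds go, whether an open chain such as n-pentyl or a 4-methoxyphenyl group would read closer to compound 1 or to compound 4 also stays open.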